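Extending the glycol ester chain of compound 2 by one unit

The compounds below may be only part of what the source reports. "The series", "measured", "known", "first", "only" and "open" are said of these compounds alone.

Measured so far:
- compound 1, `COCCOCCOCCOCCOCCOCCOCCOCCOCCOCCOC(=O)Oc1c(C(C)C)cccc1C(C)C`: > 314000 ug/mL
- compound 2, `COCCOCCOCCOCC(=O)Oc1c(C(C)C)cccc1C(C)C`: 990 ug/mL

In a physicochemical assay for solubility, in phosphate buffer, at pH 7.4 (a higher number here means a more soluble compound, a lower number a less soluble compound), compound 1 gives > 314000 ug/mL, which is a limit of the assay rather than a number. Among the compounds with values here, compound 2 gives 990 ug/mL in this assay and is therefore the only compound of the pair with an actual number. The value of compound 1 is a limit (the limit of > 314000 ug/mL in this assay, at which 1 of the 2 values shown sits). Both compounds share the same aryl ester core and differ only in the length of the methoxy-terminated glycol chain.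

Compound 3, `COCCOCCOCCOCCOCC(=O)Oc1c(C(C)C)cccc1C(C)C`, has not been measured in this assay. It differs from compound 2 by methoxymethyl in place of hydrogen on a saturated chain carbon bound to an oxygen on a saturated carbon. Within the data shown here, no step between measured compounds has been set out, so the size of this change can only be inferred from where compound 1 and compound 2 stand. Among the measured compounds shown here, since the far longer chain of compound 1 reaches the limit of this assay, the single added unit in compound 3 is expected to move solubility upward, by a modest step that may exceed the usual scatter. Compound 3 is estimated at 2500 ug/mL, with a range of 900 ug/mL to 8000 ug/mL, corresponding to the expected step of a 2.5-fold higher number from compound 2 to compound 3 (0.40 log units; beyond the scatter).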

Compound 3, solubility: 1580 ug/mL
For compound 3 the middle estimate is 1.6-fold (0.20 log units) above the measured one; measured number inside the range.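

In this assay, methoxymethyl in place of hydrogen on a saturated chain carbon bound to an oxygen on a saturated carbon gives a 1.6-fold higher number from compound 2 to compound 3 (0.20 log units; within the scatter). Within the data shown here, this is the first pair with a number on both sides, and it shows that this single added unit on the glycol chain does not produce a step that can be told apart from repeat measurements, so compound 2 and compound 3 read as equivalent in this assay. Compound 1, which carries the far longer chain and differs from the others in more than one place, still offers only a limit and not a number, so it gives no size for any step: the limit of > 314000 ug/mL in this assay, at which 1 of the 3 values shown sits.

Open, on these data alone, is whether a longer chain on the same ester, carrying several such units rather than one, would give a step beyond the scatter in this assay. Also open, as far as these compounds go, is how an amine or a carboxylic acid on the chain would read against the methoxy-terminated glycol chain of compound 2 and compound 3.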